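Working notes: aryl change on the ring nitrogen

The compounds below may be only part of what the source reports. "The series", "measured", "known", "first", "only" and "open" are said of these compounds alone.

compound 1 `COC(=O)C1=C(C)N(c2ccccc2)C=CC1c1ccccc1` in a functional assay for inhibition, using microsomes, tested at 200 ug/mL; a higher number here means a weaker effect of the compound at the concentration tested, a lower number a stronger effect: -37.3%
compound 2 `COC(=O)C1=C(C)N(c2ccccc2)C=C(C)C1c1ccccc1` in this assay: -37.4%

Going by the values given here, compound 2 and compound 1 lie within the scatter of each other; the one measured step, a number 0.1 percentage points lower from compound 1 to compound 2 (within the scatter), concerns a methyl on a double-bonded ring carbon. Compound 3 `COC(=O)C1=C(C)N(c2cccc(C)c2C)C=C(C)C1c1ccccc1` carries the change (2,3-dimethylphenyl in place of phenyl on an amine nitrogen in a ring). Among the compounds with values here, no measured step touches the aryl group on the ring nitrogen, so nothing bears directly on this change. With no contrary evidence, the step of a number 0.4 percentage points higher from compound 2 to compound 3 (within the scatter) is expected to stay within the scatter. Compound 3 is therefore estimated at -37% in this assay, with a range from -60% to -15%.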

Compound 3, a percentage reported as activity, at one concentration (the size of the read-out at that concentration, not a potency): -33.1%
Estimate against measurement, compound 3: 3.9 percentage points below; measured number inside the range.
By their numbers in this assay, from the lowest: compounds 2, 1 and 3 (each within the scatter of the next).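

In this assay, 2,3-dimethylphenyl in place of phenyl on the amine nitrogen in the ring gives a number 4.3 percentage points higher from compound 2 to compound 3 (within the scatter), so the read-out does not separate these two aryl groups at this position. With the methyl step on the double-bonded ring carbon also within the scatter, neither single change among compounds 1, 2 and 3 moves the read-out beyond it. No supporting data bear on this result.

As far as these compounds go, whether a carboxylic acid or an amine on this aryl ring would shift the read-out remains open. So does the effect of a benzyl group in place of the aryl group on the ring nitrogen.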